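The compounds below may be only part of what the source reports. "The series", "measured", "known", "first", "only" and "open" are said of these compounds alone.

Measured so far:
compound 1 `Cc1cc(O)c(C2=NN(c3ccc(S(N)(=O)=O)cc3)C(c3ccccc3Cl)C2)cc1Cl`: 16600 nM
compound 2 `COc1ccc(C2CC(c3cc(Cl)c(C)cc3O)=NN2c2ccc(S(N)(=O)=O)cc2)cc1OC`: 20200 nM

In a functional assay on HCT-15 cells (Homo sapiens) for antiproliferative activity, with a stated time of 48 h (a lower number here means a stronger inhibitor of growth, a higher number a weaker inhibitor of growth), compound 1 gives 16600 nM and compound 2 gives 20200 nM. The two numbers sit within the scatter of each other, as the step of a 1.2-fold higher number from compound 1 to compound 2 (0.09 log units; within the scatter) shows, so compound 2 cannot be set apart from compound 1 on what is known.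

Compound 3 `COc1ccc(C2CC(c3cc(Cl)c(C)cc3O)=NN2c2ccc(S(N)(=O)=O)cc2)c(OC)c1OC` differs from compound 2 in one place: methoxy in place of hydrogen on an aromatic carbon. Among the measured compounds shown here, the only measured step, a 1.2-fold higher number from compound 1 to compound 2 (0.09 log units; within the scatter), swaps the whole aryl group on the saturated ring carbon and changes nothing beyond the scatter; it is the nearest precedent, though it does not touch the same position that the methoxy enters. For the measured compounds named here, no step in the set adds a single methoxy to that ring. The expectation for compound 3 is therefore a step in this assay of about a 1.0-fold lower number from compound 2 to compound 3 (0.00 log units; within the scatter), that is, none beyond the scatter. Compound 3 is estimated at 20000 nM, with a range of 8000 nM to 50000 nM.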

Compound 3, concentration for total growth inhibition: 11800 nM
Beside the measured number, compound 3's estimate is 1.7-fold (0.23 log units) above it; the range from low to high includes it.
By their numbers in this assay, from the lowest: compounds 3, 1 and 2 (each within the scatter of the next).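

The step from 3,4-dimethoxyphenyl to 2,3,4-trimethoxyphenyl tests the aromatic carbon ortho to a large group and ortho to a methoxy group directly. In this assay it reads a 1.7-fold lower number from compound 2 to compound 3 (0.23 log units; within the scatter) and so lies within the scatter, which means a methoxy at this position leaves compound 3 not distinguishable from compound 2. Against the 2-chlorophenyl group, the 2,3,4-trimethoxyphenyl group reads a 1.4-fold lower number from compound 1 to compound 3 (0.15 log units; within the scatter) and this too lies within the scatter, so the three aryl groups on the saturated ring carbon cannot be set apart in this assay and no ranking among them can be drawn; nothing is available that would explain these readings.

Open, as far as these compounds go, is whether any group at this aromatic carbon can move the number beyond the scatter, since only hydrogen and methoxy are compared there, and an amine or a carboxylic acid would be a sharper test than methoxy. Also open, from the compounds shown here alone, is whether the flat reading holds with the other ring of the core changed, as every compound here carries the same chloro, methyl and hydroxyl substituted ring.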